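Bromo on the thiophene of a coumarin adenosine A2b antagonist

The source may hold more compounds than are shown below. What is called first, only, known or untested is meant among the compounds shown, and "the series" means these compounds.

Measured compounds:
Compound 1, `CC(=O)Oc1cccc2cc(-c3cccs3)c(=O)oc12`, in a functional assay on isolated protein for antagonist activity at adenosine receptor A2b (Homo sapiens) (a lower number here means a stronger inhibitor, a higher number a weaker inhibitor), gives > 30000 nM, a limit of the assay.
Compound 2, `O=c1oc2c(O)cccc2cc1-c1cccs1`, in this assay gives > 30000 nM, a limit of the assay.
Compound 3, `O=c1oc2c(O)c(O)ccc2cc1-c1cccs1`, in this assay gives > 30000 nM, a limit of the assay.

Compound 2 therefore stands not on a number but on a limit, and the two other values shown stand on the same limit, so nothing separates it from compound 1 or compound 3 on what is known. The step that the two limits leave unreadable from compound 1 to compound 2 and the step that the two limits leave unreadable from compound 2 to compound 3 are both left unreadable, because of the limit of > 30000 nM in this assay, at which 3 of the 3 values shown sit.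

The unmeasured compound 4, `O=c1oc2c(O)cccc2cc1-c1cc(Br)cs1`, differs from compound 2 by bromo in place of hydrogen on an aromatic carbon, on the ring attached to the shared core rather than on the core itself. Among the measured compounds shown here, both measured steps touch the core and neither is readable, so they give no direction for this change; no measured step touches the thiophene ring. The expectation for the step of a number no higher from compound 2 to compound 4 (the limit leaves the size open) is thus that it remains unreadable too, and the estimate rests on the limit alone.

Compound 4 is expected to give 30000 nM in this assay, with a range from 5000 nM to 100000 nM, most likely reported only as a limit.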

Compound 4, inhibition constant: > 30000 nM
Compound 4: only a limit was reported; the forecaster's own chance of this, stated with the estimate: 75%; the middle value sits exactly at the limit.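

No new step can be read from compound 2 to compound 4 in this assay, because both stand on the same limit of the assay: the limit of > 30000 nM in this assay, at which 4 of the 4 values shown sit.

The compounds shown leave open how strongly any of them acts in this assay, and whether bromo on the thiophene changes that at all.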